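The source may report more compounds than this note shows. Statements on the series, on what has been measured and on what is new or still open speak of the compounds shown alone.

Compound 1 `COC(=O)C[C@H](NC(=O)OC(C)(C)C)C(=O)N(Cc1ccccc1)C1(C(=O)NCc2ccccc2)CCN(Cc2ccccc2)CC1` was examined in an ADME assay on MDCK cells (Canis lupus familiaris) for cytotoxicity, read by microscopy, with a stated time of 72 h; on this read-out lower numbers stand for higher toxicity in this test and higher numbers for lower toxicity in this test. In this assay compound 1 gives > 100000 nM, which is a limit of the assay rather than a measured number, as the record the limit of > 100000 nM in this assay, at which 1 of the 3 values shown sits, shows. Two close relatives of compound 1 each carry a single change on an aromatic carbon. Compound 2 `COC(=O)C[C@H](NC(=O)OC(C)(C)C)C(=O)N(Cc1ccc([N+](=O)[O-])cc1)C1(C(=O)NCc2ccccc2)CCN(Cc2ccccc2)CC1` gives 20000 nM in this assay, and compound 3 `COC(=O)C[C@H](NC(=O)OC(C)(C)C)C(=O)N(Cc1ccccc1F)C1(C(=O)NCc2ccccc2)CCN(Cc2ccccc2)CC1` gives 20000 nM. The step of an at least 5.0-fold lower number from compound 1 to compound 2 (0.69 log units; beyond the scatter) and the step of an at least 5.0-fold lower number from compound 1 to compound 3 (0.69 log units; beyond the scatter) both move the number down, whereas no change at the digits printed from compound 2 to compound 3 (within the scatter).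

Compound 4 `CC(C)(C)OC(=O)N[C@@H](CC(N)=O)C(=O)N(Cc1ccccc1)C1(C(=O)NCc2ccccc2)CCN(Cc2ccccc2)CC1` changes compound 1 in a different place: amino in place of methoxy on a carbonyl carbon. Neither measured step touches a carbonyl carbon, so none of them bears directly on this change, and the starting point is itself only a limit. The expectation is therefore a step of a number no higher from compound 1 to compound 4 (the limit leaves the size open), within the scatter, with compound 4 most likely again at the limit. Compound 4 is estimated at 100000 nM in this assay, with a range from 40000 nM to 200000 nM.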

Compound 4, minimum cytotoxic concentration: > 100000 nM
Compound 4: only a limit was reported; the forecaster's own chance of this, stated with the estimate: 70%; the middle value sits exactly at the limit.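

No new step can be read between compound 1 and compound 4, as each gives a limit of the assay rather than a number: the limit of > 100000 nM in this assay, at which 2 of the 4 values shown sit. The compounds shown leave open how far, if at all, amino in place of methoxy on a carbonyl carbon shifts the read-out in this assay.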